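Solubility of a para-substituted phenyl oxazole amide series

The source may report more compounds than this note shows. Statements on the series, on what has been measured and on what is new or still open speak of the compounds shown alone.

Measured compounds in a physicochemical assay for solubility, in phosphate buffer, measured as kinetic solubility, at pH 7.4; on this read-out higher numbers stand for higher solubility and lower numbers for lower solubility:
Compound 1 `Cc1ccccc1-c1nc(CN2CCC(C(=O)NCCCN3CCC(C)(C)CC3)CC2)c(C)o1` gives > 69 ug/mL, a limit of the assay and not a number.
Compound 2 `Cc1oc(-c2ccc(Cl)cc2)nc1CN1CCC(C(=O)NCCCN2C[C@H](C)C[C@H](C)C2)CC1` gives > 72 ug/mL, again a limit of the assay.
Compound 3 `Cc1ccccc1-c1nc(CN2CCC(C(=O)NCCCN3[C@H](C)CCC[C@@H]3C)CC2)c(C)o1` gives > 69 ug/mL, also a limit of the assay.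

All three measured values are limits, so none of them gives a number to place compound 2 against; it simply sits at one of the two limits, as the limit of > 72 ug/mL in this assay, at which 1 of the 3 values shown sits, records, while the other two compounds sit at the limit of > 69 ug/mL in this assay, at which 2 of the 3 values shown sit. Going by the values given here, the only single-point step among them, a step that the two limits leave unreadable from compound 1 to compound 3, cannot be read in size for the same reason.

Compound 4 `Cc1ccc(-c2nc(CN3CCC(C(=O)NCCCN4C[C@H](C)C[C@H](C)C4)CC3)c(C)o2)cc1` is not yet measured. It differs from compound 2 by methyl in place of chloro on an aromatic carbon. Among the compounds with values here, no measured step shows this change, and the step from compound 1 to compound 3 concerns a different position, so it gives no guidance in size or direction. With every measured compound at a limit, the expectation is that compound 4 also reaches that limit, and the estimated step of an at least 1.0-fold lower number from compound 2 to compound 4 (0.01 log units; that floor lies within the scatter) is expected to lie within the scatter. Compound 4 is therefore estimated at 70 ug/mL, with a range from 40 ug/mL to 120 ug/mL.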

Compound 4, solubility: > 69 ug/mL
Compound 4 was reported as a limit; the forecaster's own chance of this, stated with the estimate: 80%; the middle value does not contradict the limit.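

Compound 2 and compound 4 are both reported only as limits of the assay in this assay, not as numbers, so the step between them, methyl in place of chloro, cannot be read in size or direction. The compounds shown leave open how far any of them actually dissolves, and whether this exchange matters at all.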